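The source may report more compounds than this note shows. Statements on the series, on what has been measured and on what is new or still open speak of the compounds shown alone.

Of the compounds shown here, three have so far been tested in a functional assay on HPLF cells (Homo sapiens) for cytotoxicity; on this read-out higher numbers stand for lower toxicity in this test and lower numbers for higher toxicity in this test. Compound 1 `COc1ccc(/C=C2\CCC/C(=C\c3ccc([N+](=O)[O-])cc3)C2=O)cc1` gives only a limit of the assay, > 400000 nM, rather than a number. Compound 3 `COc1cc(/C=C2/C(=O)/C(=C/c3ccc([N+](=O)[O-])cc3)c3ccccc32)cc(OC)c1OC` likewise reaches only a limit, > 400000 nM. Going by the values given here, compound 2 `O=C1/C(=C/c2ccc(O)cc2)Cc2ccccc2/C1=C\c1ccc([N+](=O)[O-])cc1` is the one with a measured number: in this assay compound 2 gives 75000 nM. Compound 1 thus stands at the limit of > 400000 nM in this assay, at which 2 of the 3 values shown sit. Since the values of compound 1 and compound 3 are limits, no order can be drawn between them, and only compound 2 shows a number within the measurable range.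

Compound 4 `COc1cc(/C=C2\CCC/C(=C\c3ccc([N+](=O)[O-])cc3)C2=O)ccc1O` has not yet been measured. Compared with compound 1, the structural change is 4-hydroxy-3-methoxyphenyl in place of 4-methoxyphenyl on a double-bonded chain carbon bound to a double-bonded ring carbon. Among the compounds with values here, the cores of the three measured compounds differ, and no pair of them differs in a single place, so no measured step is available as a guide for this change.

On the numbers shown, the cytotoxicity of compound 4 is expected to remain close to that of compound 1, so the step is expected to be an at least 1.3-fold lower number from compound 1 to compound 4 (0.12 log units; that floor lies within the scatter), which would lie within the usual scatter. Compound 4 is therefore estimated at 300000 nM, with a range from 80000 nM to 400000 nM, and a fair chance that only a limit is reported.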

Compound 4, half-maximal cytotoxic concentration: 171000 nM
Estimate against measurement, compound 4: 1.8-fold (0.24 log units) above; the measured number falls inside the stated range.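

In this assay, going by these compounds alone, the first step that can be read at this position, on a double-bonded chain carbon bound to a double-bonded ring carbon, comes from putting 4-hydroxy-3-methoxyphenyl in place of 4-methoxyphenyl: an at least 2.3-fold lower number from compound 1 to compound 4 (0.36 log units; beyond the scatter). On this read-out a lower number stands for higher toxicity, and compound 4 gives 171000 nM, a measured number rather than a limit, so this one change on the shared core is enough to bring the result inside the measurable range. The true size of the step stays unknown because compound 1 gives only a limit of the assay, not a number: the limit of > 400000 nM in this assay, at which 2 of the 4 values shown sit.

The entering group differs from the leaving one in two ways, carrying a hydroxy group and an added methoxy group, and the compounds shown do not separate what each contributes. They also leave open whether an aminophenyl or a phenyl bearing a carboxylic acid at this place would move the number further, and whether the same change would do the same on the cores of compound 2 and compound 3.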